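The source may report more compounds than this note shows. Statements on the series, on what has been measured and on what is new or still open speak of the compounds shown alone.

Compound 2 `Cc1ccc(CNC(=O)c2cccc(C(C)Oc3cccnc3Nc3nccs3)c2)cc1` belongs to a small series built on a shared core, alongside compound 1 `Cc1ccc(CNC(=O)c2cccc(C(C)Oc3cccnc3Nc3cnn(CC(C)(C)O)c3)c2)cc1`. In a functional assay on HCC78 cells (Homo sapiens) for antiproliferative activity, read by MTT assay, with a stated time of 48 h (a higher number here means a weaker inhibitor, a lower number a stronger inhibitor), compound 1 gives 20500 nM, and in this assay compound 2 gives 27100 nM. The two sit within the scatter of each other, as the step of a 1.3-fold higher number from compound 1 to compound 2 (0.12 log units; within the scatter) shows, so compound 2 cannot be set apart from compound 1 on these numbers. Compound 3 `Cc1ccc(CNC(=O)c2cccc(C(C)Oc3cccnc3Nc3cnn(CC#N)c3)c2)cc1` has not yet been measured. It differs from compound 2 by 1-(cyanomethyl)-1H-pyrazol-4-yl in place of 1,3-thiazol-2-yl on a nitrogen on an aromatic ring. For the measured compounds named here, the only measured step that bears on this change is the one from compound 1 to compound 2, which also exchanged a substituted pyrazolyl for the thiazolyl at the same nitrogen and moved the number by a 1.3-fold higher number from compound 1 to compound 2 (0.12 log units; within the scatter). Since that exchange produced nothing beyond the scatter, the return to a pyrazolyl, now carrying a cyanomethyl group, is expected to give a step of a 1.2-fold lower number from compound 2 to compound 3 (0.09 log units; within the scatter), that is, no clear movement in either direction. Compound 3 is therefore estimated at 22000 nM in this assay, with a likely range from 8000 nM to 60000 nM.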

Compound 3, half-maximal inhibitory concentration: 57400 nM
Beside the measured number, compound 3's estimate is 2.6-fold (0.42 log units) below it; low and high end bracket the measured number.
By their numbers in this assay, from the lowest: compounds 1 and 2 (each within the scatter of the next); then compound 3.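

In this assay the group on the nitrogen on an aromatic ring turns out to be able to move the number beyond the scatter: 1-(cyanomethyl)-1H-pyrazol-4-yl in place of 1,3-thiazol-2-yl gives a 2.1-fold higher number from compound 2 to compound 3 (0.33 log units; beyond the scatter) and so a modest loss, which the earlier exchange at this nitrogen did not show. The pyrazolyl ring alone does not settle the outcome, since cyano in place of 1-hydroxy-1-methylethyl on a saturated chain carbon bound to an aromatic nitrogen gives a 2.8-fold higher number from compound 1 to compound 3 (0.45 log units; beyond the scatter) as a further modest step. Nothing measured here explains either step.

From the compounds shown here alone, whether a primary amine or a carboxylic acid at the end of that chain would lower or raise the number remains open. So does the effect of a longer chain carrying the same cyano group.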